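A chloro added to a compound at the limit

The compounds below may be only part of what the source reports. "The series", "measured", "known", "first", "only" and "open" are said of these compounds alone.

Compound 1 (`O=C(Nc1cccc(-n2cc(-c3ccncc3)c(-c3ccc(Cl)c(O)c3)n2)c1)Nc1cccc(C(F)(F)F)c1`) : 19100 nM
Compound 2 (`COc1cc(-c2nn(-c3cccc(NC(=O)c4cccc(C(F)(F)F)c4)c3)cc2-c2ccncc2)ccc1Cl`) : > 50000 nM (a limit)

In a functional assay on UACC-257 cells (Homo sapiens) for inhibition, read by sulforhodamine B assay, with a stated time of 48 h (on this read-out lower numbers stand for stronger inhibition of growth and higher numbers for weaker inhibition of growth), compound 2 stands at > 50000 nM, which is a limit of the assay and not a number.

Compound 3 (`COc1cc(-c2nn(-c3cccc(NC(=O)c4ccc(Cl)c(C(F)(F)F)c4)c3)cc2-c2ccncc2)ccc1Cl`) differs from compound 2 in one place: chloro in place of hydrogen on an aromatic carbon, with chloro in place of hydrogen on an aromatic carbon. For the measured compounds named here, no measured step shows what this change does, so only a small move toward stronger inhibition of growth is expected in this assay, perhaps none beyond the scatter. The estimate means an at least 1.2-fold lower number from compound 2 to compound 3 (0.09 log units; that floor lies within the scatter) as the expected step. For compound 3 the estimated value is 40000 nM (expected range 15000 nM to 100000 nM), and the assay may again report only a limit.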

Compound 3, concentration for total growth inhibition: > 32500 nM
Compound 3 was reported as a limit; the forecaster's own chance of this, stated with the estimate: 55%; the middle value is on the limit's open side.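

Compound 3 gives > 32500 nM, which is a limit of the assay and not a number. Compound 2 gives > 50000 nM, also a limit, and no step can be read between compound 2 and compound 3. From the compounds shown here alone, whether the added chloro changes growth inhibition in this assay stays open.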